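The source may hold more compounds than are shown below. What is called first, only, known or untested is meant among the compounds shown, and "the series" means these compounds.

Measured so far:
Compound 1 `O=C1NC2(CC2c2ccc3cccc(OCc4ccccc4)c3n2)C(=O)N1c1ccc(Cl)cc1` — 300 mg/kg
Compound 2 `Cc1ccc(N2C(=O)NC3(CC3c3ccc4cccc(OCc5ccccc5)c4n3)C2=O)cc1` — 100 mg/kg
Compound 3 `CCC(CO)N1C(=O)NC2(CC2c2ccc3cccc(OCc4ccccc4)c3n2)C1=O` — 30 mg/kg

The three compounds share one core and differ only in the group on an amide-type nitrogen in a ring. In a functional assay on the whole organism (strain Kunming) with Mus musculus as the target, in the maximal electroshock model, with a stated time of 0.5 h (on this read-out lower numbers stand for an effect already at smaller amounts and higher numbers for an effect only at larger amounts of compound), compound 3 gives the lowest number of the three: a 3.3-fold lower number from compound 2 to compound 3 (0.52 log units; beyond the scatter), and a 10-fold lower number from compound 1 to compound 3 (1.00 log units; beyond the scatter). Among the two aryl groups, a 3.0-fold lower number from compound 1 to compound 2 (0.48 log units; beyond the scatter).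

Compound 4 `CN1C(=O)NC2(CC2c2ccc3cccc(OCc4ccccc4)c3n2)C1=O` is not yet measured. It differs from compound 3 by methyl in place of 1-(hydroxymethyl)propyl on an amide-type nitrogen in a ring. For the measured compounds named here, no measured step exchanges one alkyl group for another, so the only guidance is indirect: both steps onto compound 3 replaced an aryl group with the 1-(hydroxymethyl)propyl group and gave lower numbers. Methyl keeps an alkyl group on that nitrogen but drops the hydroxyl and three of the four carbons, so the expectation is a modest rise, less than the aryl steps: in this assay compound 4 is expected to give 60 mg/kg, within 20 mg/kg to 200 mg/kg. That estimate means a 2.0-fold higher number from compound 3 to compound 4 (0.30 log units; within the scatter).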

Compound 4, minimum effective dose: 100 mg/kg
For compound 4 the middle estimate is 1.7-fold (0.22 log units) below the measured one, and the stated range covers the measured number.
By their numbers in this assay, from the lowest: compound 3; then compounds 2 and 4 (each within the scatter of the next); then compound 1.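

In this assay, for the compounds shown here, this is the first step that stays among alkyl groups on the amide-type nitrogen, and trading 1-(hydroxymethyl)propyl for methyl gives a 3.3-fold higher number from compound 3 to compound 4 (0.52 log units; beyond the scatter). An alkyl group at this position is therefore not enough on its own to reach the lowest number: methyl in place of 4-methylphenyl gives no change at the digits printed from compound 2 to compound 4 (within the scatter), although methyl in place of 4-chlorophenyl gives a 3.0-fold lower number from compound 1 to compound 4 (0.48 log units; beyond the scatter). The hydroxyl and the extra carbons leave together in the step to methyl, so that step cannot separate their contributions.

No measurement here explains these differences. Still open, on these data alone, is whether a plain propyl chain without the hydroxyl, a short 2-hydroxyethyl chain, or an amine in place of the hydroxyl would keep the number of compound 3.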